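Phenyl in Place of Butoxy on a Shared Core

The source may hold more compounds than are shown below. What is called first, only, known or untested is meant among the compounds shown, and "the series" means these compounds.

Measured so far:
Compound 1, `Cc1ccc(-c2nc3c(=O)n(C)c(=O)n(C)c3[nH]2)c(N)c1`: in an assay for binding affinity to adenosine receptor A1 (Bos taurus) (a higher number here means a weaker inhibitor, a lower number a stronger inhibitor), compound 1 gives 10 nM
Compound 2, `CCCCOc1ccc(-c2nc3c(=O)n(C)c(=O)n(C)c3[nH]2)cc1`: in this assay compound 2 gives 4 nM
Compound 3, `COc1ccc(-c2nc3c(=O)n(C)c(=O)n(C)c3[nH]2)cc1OC`: in this assay compound 3 gives 22.5 nM

Compound 2 has the lowest number of the three in this assay. Compound 1 stands nearest, with a higher number that lies beyond the usual scatter, and compound 3 stands furthest, also beyond the scatter. Compound 4, `Cn1c(=O)c2nc(-c3ccc(-c4ccccc4)cc3)[nH]c2n(C)c1=O`, is not yet measured. It differs from compound 2 in one place: phenyl in place of butoxy on an aromatic carbon. Among the measured compounds shown here, no measured pair isolates this change, so the step is open. The expectation is a modest rise in the number, near the edge of the scatter, giving an expected step of a 2.3-fold higher number from compound 2 to compound 4 (0.35 log units; beyond the scatter). Compound 4 is therefore estimated at 9 nM, expected to fall between 2.5 nM and 35 nM.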

Compound 4, half-maximal inhibitory concentration: 3.5 nM
Beside the measured number, compound 4's estimate is 2.6-fold (0.41 log units) above it, within the range that was stated.
By their numbers in this assay, from the lowest: compounds 4 and 2 (each within the scatter of the next); then compound 1; then compound 3.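

In this assay, phenyl in place of butoxy on this aromatic carbon, para to a large group, gives a 1.1-fold lower number from compound 2 to compound 4 (0.06 log units; within the scatter) and leaves the two compounds indistinguishable. This position therefore accepts a six-membered aromatic ring of carbon only as readily as the butoxy chain, despite the loss of the oxygen. No evidence is available to explain this match. The compounds shown leave open whether a carboxylic acid, a nitrile or a longer chain at this carbon would also hold the number.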